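This account rests on a few compounds, and the source may have more. Where it says the series, first, only, none or still open, it means among the compounds named here.

Working notes on the series. Compound 1, `Cc1nc(S(C)(=O)=O)ccc1Oc1ncnc(OC2CCN(C(=O)OC(C)(C)C(F)(F)F)CC2)c1F`, and compound 2, `Cc1nc(S(C)(=O)=O)ccc1Oc1ncnc(OC2CCN(C(=S)OC(C)C)CC2)c1F`, share the same core and differ only at the amine nitrogen in the ring. In a functional assay on isolated protein for inhibition of Glucose-dependent insulinotropic receptor (Rattus norvegicus), read by HTRF and cAMP accumulation (a lower number here means that less compound is needed, a higher number that more compound is needed for the effect), compound 1 gives 47.2 nM. In this assay, going by the values given here, compound 2 gives 1050 nM, the highest of the two numbers measured so far. Among the compounds with values here, the single step measured, a 22-fold higher number from compound 1 to compound 2 (1.35 log units; beyond the scatter), is large and beyond the scatter. Compound 3, `Cc1nc(S(C)(=O)=O)ccc1Oc1ncnc(OC2CCN(C(=O)C(F)(F)F)CC2)c1F`, is the next candidate; its change from compound 2 is a group of 6 heavy atoms (2 carbon, 1 oxygen, 3 fluorine; no ring) in place of a group of 6 heavy atoms (4 carbon, 1 oxygen, 1 sulfur; no ring), on an amine nitrogen in a ring. The entering group brings back a carbonyl and a trifluoromethyl, both present in compound 1 and absent from compound 2, though the full group of compound 1 is not restored. Within the data shown here, the only step bearing on this change is a 22-fold higher number from compound 1 to compound 2 (1.35 log units; beyond the scatter), which it partly reverses, so a downward step in this assay is expected, smaller than that measured one. The expected step from compound 2 to compound 3 is a 7.0-fold lower number from compound 2 to compound 3 (0.85 log units; beyond the scatter). For compound 3 the estimated value in this assay is 150 nM, with a range from 40 nM to 600 nM.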

Compound 3, half-maximal effective concentration: 880 nM
The estimate for compound 3 lay 5.9-fold (0.77 log units) below the measured number; the whole stated range lies below it.
By their numbers in this assay, from the lowest: compound 1; then compounds 3 and 2 (each within the scatter of the next).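

In this assay, the step to (trifluoromethyl)carbonyl on the amine nitrogen in the ring is a 1.2-fold lower number from compound 2 to compound 3 (0.08 log units; within the scatter), so a carbonyl and a trifluoromethyl together do not bring this series back to the number of compound 1. The comparison at the carbonyl carbon, a 19-fold higher number from compound 1 to compound 3 (1.27 log units; beyond the scatter), is large, as is a 22-fold higher number from compound 1 to compound 2 (1.35 log units; beyond the scatter), so both groups that replace the one in compound 1 give numbers beyond the scatter from it; among these three compounds, the lowest number goes only with the complete 1-methyl-1-(trifluoromethyl)ethoxy carbonyl group. No measurement is available that explains these differences.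

The compounds shown do not separate the contribution of the oxygen joined to the carbonyl from that of the branched carbon and its trifluoromethyl, a question that tert-butoxycarbonyl on the same nitrogen would address. Compound 2 also differs from compound 1 in more than one feature of its group, so isopropoxycarbonyl would be needed to set the sulfur apart from the loss of the fluorines.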